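Lengthening the Amide Tether: From Compound 3 to Compound 4

The source may hold more compounds than are shown below. What is called first, only, known or untested is meant among the compounds shown, and "the series" means these compounds.

Measured compounds in an assay on isolated protein for inhibition of Amine oxidase [flavin-containing] B (Homo sapiens), read by fluorescence and spectrophotometry; on this read-out lower numbers stand for stronger inhibition and higher numbers for weaker inhibition:
- compound 1, `O=C(NCc1cn(Cc2ccc3oc(-c4ccccc4)cc(=O)c3c2)nn1)c1ccccc1`, gives 15600 nM
- compound 2, `Cc1ccc(C(=O)NCc2cn(Cc3ccc4oc(-c5ccc(Cl)cc5)cc(=O)c4c3)nn2)cc1`, gives 32900 nM
- compound 3, `Cc1ccc(NC(=O)CCc2cn(Cc3ccc4oc(-c5ccccc5)cc(=O)c4c3)nn2)cc1`, gives 15600 nM

Compound 3 stands level with compound 1 at the digits shown, and the two together hold the lowest numbers of the three; compound 2 sits furthest from compound 3, with a higher number beyond the scatter. Compound 4, `Cc1ccc(NC(=O)CCCCc2cn(Cc3ccc4oc(-c5ccccc5)cc(=O)c4c3)nn2)cc1`, differs from compound 3 in this way: a group of 12 heavy atoms (10 carbon, 1 nitrogen, 1 oxygen; one six-membered aromatic ring of carbon only) in place of a group of 10 heavy atoms (8 carbon, 1 nitrogen, 1 oxygen; one six-membered aromatic ring of carbon only), on a saturated chain carbon, two bonds along the chain from an aromatic carbon. For the measured compounds named here, only one measured step touches the same part of the molecule, no change at the digits printed from compound 1 to compound 3 (within the scatter), and that step swapped one group for another rather than lengthening a chain; it showed no change beyond the scatter. Going by the values given here, no measured pair reports a chain extension of this kind, so the data give no direction for it. On that basis a step of no size beyond the scatter is expected, no change at the digits printed from compound 3 to compound 4 (within the scatter). Compound 4 is therefore estimated at 15600 nM in this assay, within a range from 6000 nM to 40000 nM.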

Compound 4, half-maximal inhibitory concentration: 15600 nM
Estimate against measurement, compound 4: no gap at the digits printed, within the range that was stated.
By their numbers in this assay, from the lowest: compounds 1, 3 and 4 (each within the scatter of the next); then compound 2.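

In this assay the only chain extension among the compounds shown gave no change at the digits printed from compound 3 to compound 4 (within the scatter), so at this place, on a saturated chain carbon, two bonds along the chain from an aromatic carbon, the group of 12 heavy atoms reads the same as the group of 10 heavy atoms. Taken with no change at the digits printed from compound 1 to compound 3 (within the scatter) this leaves no step beyond the scatter at this part of the molecule among the compounds shown. No measurement at hand offers a reason for this flat result.

As far as these compounds go, whether a still longer chain would shift the number in this assay stays open. So does the effect of an amine or a carboxylic acid in place of the (4-methylphenyl)carbamoyl group, since every change at this place shown so far keeps that 4-methylphenyl ring or a benzamido group.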